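The source may report more compounds than this note shows. Statements on the series, on what has been measured and on what is new or still open speak of the compounds shown alone.

Of the compounds shown here, three from this series have been tested so far in an ADME assay on HepG2 cells (Homo sapiens) for cytotoxicity, with a stated time of 72 h; a lower number here means that less compound is needed, a higher number that more compound is needed for the effect. Compound 1, `CSc1ccc(NC(=O)Nc2cc(C)nc3ccccc23)cc1`, gives 16000 nM. Compound 2, `Cc1cc(NC(=O)Nc2cccc(C(N)=O)c2)c2ccccc2n1`, reaches only > 25000 nM, which is a limit of the measurement rather than a number. Compound 3, `Cc1cc(NC(=O)Nc2ccc(C(=O)O)c(O)c2)c2ccccc2n1`, likewise returns only > 25000 nM, again a limit. So compound 2 does not stand apart from its neighbours; it sits at the limit of > 25000 nM in this assay, at which 2 of the 3 values shown sit, and compound 1 is the only one of the three with a numerical reading.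

The next compound, compound 4, `Cc1cc(NC(=O)Nc2cccc(Cl)c2)c2ccccc2n1`, is built from compound 2 by one change: chloro in place of carbamoyl on an aromatic carbon. Within the data shown here, no pair of measured compounds differing in a single place exists here, so the size of this step cannot be read from data already in hand. The expected step from compound 2 to compound 4, an at least 1.6-fold lower number from compound 2 to compound 4 (0.22 log units; that floor lies within the scatter), is modest and could go either way within the usual scatter. On that basis, compound 4 is estimated to give about 15000 nM in this assay, with a plausible range from 5000 nM to 40000 nM.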

Compound 4, half-maximal effective concentration: 19000 nM
Compound 4: middle estimate off by 1.3-fold (0.10 log units), on the low side; measured number inside the range.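

Among these compounds, this is the first change at a single place that can be read: in this assay, chloro in place of carbamoyl on this aromatic carbon gives an at least 1.3-fold lower number from compound 2 to compound 4 (0.11 log units; that floor lies within the scatter). Only the floor of that step is known, and its full size stays hidden because compound 2 sits at a limit of the measurement: the limit of > 25000 nM in this assay, at which 2 of the 4 values shown sit.

At this position, compound 4 gives 19000 nM, a true number rather than a limit, so a numerical reading now exists for later changes here to be compared with.

From the compounds shown here alone, whether the real step goes beyond the usual scatter remains open. Also open, going by these compounds, is how much of any change comes from losing carbamoyl and how much from adding chloro, a question that a plain hydrogen, an amine or a nitrile at this same place could help to settle.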